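The source may report more compounds than this note shows. Statements on the series, on what has been measured and on what is new or still open speak of the compounds shown alone.

Working notes on the urea series. Three compounds have numbers in a functional assay on MDA-MB-231 cells (Homo sapiens) for cytotoxicity, read by MTT assay, with a stated time of 72 h; on this read-out lower numbers stand for stronger inhibition and higher numbers for weaker inhibition. Compound 1 `CN(C)CCCNc1nc(-c2ccc(NC(=O)Nc3ccc(Cl)cc3)cc2)nc2c(Cl)c(Cl)sc12` gives 1160 nM in this assay. Compound 2 `Cc1ccc(NC(=O)Nc2ccc(-c3nc(NCCN(C)C)c4sccc4n3)cc2)cc1` gives 2180 nM in this assay. Compound 3 `CCN(CC)CCCNc1nc(-c2ccc(NC(=O)Nc3ccccc3)cc2)nc2c(Cl)c(Cl)sc12` gives 1780 nM in this assay, which is the second highest of the three numbers; its nearest neighbour is compound 2, and the gap between them lies within the scatter, while the gap to compound 1, the furthest of the three, also lies within the scatter. On these numbers all three compounds sit together.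

The next compound, compound 4 `CCN(CC)CCCNc1nc(-c2ccc(NC(=O)Nc3ccc(Cl)cc3)cc2)nc2c(Cl)c(Cl)sc12`, differs from compound 3 in one place: chloro in place of hydrogen on an aromatic carbon. Within the data shown here, no pair among the measured compounds differs only in this way, so no matched step is available to read the size of the change from. Compound 1, which carries the same chloro group but a different amine chain, and compound 3 differ by less than the scatter, which suggests the change carries no large weight here. The step from compound 3 to compound 4 is therefore expected to be small, a 1.3-fold lower number from compound 3 to compound 4 (0.10 log units; within the scatter), with no direction claimed beyond the scatter. Compound 4 is estimated at 1400 nM in this assay, within a range of 700 nM to 2800 nM.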

Compound 4, half-maximal inhibitory concentration: 660 nM
Estimate against measurement, compound 4: 2.1-fold (0.33 log units) above; the whole stated range lies above it.
By their numbers in this assay, from the lowest: compounds 4, 1, 3 and 2 (each within the scatter of the next, the first and the last beyond it).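

In this assay, among these compounds, the change from phenylcarbamoyl to (4-chlorophenyl)carbamoyl gives the first matched reading at this position: a 2.7-fold lower number from compound 3 to compound 4 (0.43 log units; beyond the scatter), a modest step that lies beyond the scatter. Diethylamino in place of dimethylamino, read as a 1.8-fold lower number from compound 1 to compound 4 (0.24 log units; within the scatter), stays within the scatter, so this pair shows no readable weight for that change at the end of the chain. No measured evidence on hand bears on either step.

As far as these compounds go, the chloro step rests on a single pair with the diethylamino chain, so whether it carries over to the dimethylamino chain remains open. Also open, from the compounds shown here alone, is how fluoro, methoxy or a carboxylic acid would read at the same place on the ring, and how a longer chain would read on the amine side.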